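Hydroxyalkyl versus allyl on the piperidine-type chain

A few compounds are considered here, and "the series" means these few. Any claim that something is new, unique, unknown or untested is made for them only; others in the source may bear on it.

Measured so far:
compound 1, `Cn1ncc(Cl)c1-c1cc(C(=O)N[C@@H]2CN[C@H](CCO)C[C@H]2c2ccc(F)c(F)c2)oc1Cl`: 0.98 nM
compound 2, `C=CC[C@@H]1C[C@@H](c2ccc(Cl)c(Cl)c2)[C@H](NC(=O)c2cc(-c3c(Cl)cnn3C)c(Cl)o2)CN1`: 12.4 nM

In an assay for inhibition of RAC-alpha serine/threonine-protein kinase (Homo sapiens), read by HTRF, with a stated time of 1 h (on this read-out higher numbers stand for weaker inhibition and lower numbers for stronger inhibition), compound 2 gives 12.4 nM, the higher of the two numbers recorded; compound 1 gives 0.98 nM, a gap beyond the scatter. Compound 3, `Cn1ncc(Cl)c1-c1cc(C(=O)N[C@@H]2CN[C@H](CCCO)C[C@H]2c2ccc(Cl)c(Cl)c2)oc1Cl`, is not yet measured. It differs from compound 2 by 2-hydroxyethyl in place of vinyl on a saturated chain carbon bound to a saturated ring carbon; the same change, cut one bond further out, reads allyl to 3-hydroxypropyl. Compound 1, which carries a hydroxyl-bearing chain, gives the lower number, 0.98 nM, so the step from compound 2 to compound 3 is expected to go down, a 4.1-fold lower number from compound 2 to compound 3 (0.62 log units; beyond the scatter), beyond the scatter. Compound 3 is estimated at 3 nM, within 1 nM to 12 nM.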

Compound 3, half-maximal inhibitory concentration: 2.56 nM
Compound 3: the middle estimate sits 1.2-fold (0.07 log units) above what was measured; the measured number falls inside the stated range.
By their numbers in this assay, from the lowest: compound 1; then compound 3; then compound 2.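

In this assay 2-hydroxyethyl in place of vinyl on a saturated chain carbon bound to a saturated ring carbon gives a 4.8-fold lower number from compound 2 to compound 3 (0.69 log units; beyond the scatter) with the rest of the structure unchanged. Within the data shown here, this is the first single-place reading at this position, which compound 1 could not give, as it differs from compound 2 in more than one place. No measurement shown explains the step.

Open, going by these compounds, is how a plain propyl chain would read here, which would separate the loss of the double bond from the gain of the hydroxyl. Also open, on these data alone, is whether a terminal amine or carboxylic acid on the same chain would match the hydroxyl.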